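Swapping chloro for nitro on an amide-bearing benzamide series

A few compounds are considered here, and "the series" means these few. Any claim that something is new, unique, unknown or untested is made for them only; others in the source may bear on it.

Three compounds share a core and differ in a benzamide group hanging from a phenyl ring. Compound 1 `COc1cc2oc(-c3cccc(NC(=O)c4ccc(C(F)(F)F)cc4)c3)cc(=O)c2c(OC)c1OC` carries a trifluoromethyl on its benzamide and is reported in a functional assay on UO-31 cells (Homo sapiens) for inhibition, read by sulforhodamine B assay, tested at 10 uM (on this read-out higher numbers stand for more inhibition at the one concentration tested (going by the name of the read-out) and lower numbers for less inhibition), only as "active" (no number reported), without a number. Compound 2 `COc1cc2oc(-c3cccc(NC(=O)c4ccc(Cl)cc4)c3)cc(=O)c2c(OC)c1OC` carries a chloro instead and gives 51.1% in this assay. Compound 3 `COc1cc2oc(-c3ccc(NC(=O)c4ccc(Cl)cc4)cc3)cc(=O)c2c(OC)c1OC` keeps that chloro but attaches the amide at another position of the phenyl ring; in this assay compound 3 is reported as "active" (no number reported), again with no number, so it stands without a single figure, as does compound 1. No pair of these compounds has a computed step between measured values, so only the single number of compound 2 anchors the series.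

Compound 4 `COc1cc2oc(-c3ccc(NC(=O)c4ccc([N+](=O)[O-])cc4)cc3)cc(=O)c2c(OC)c1OC` is the next member. Compared with compound 3 it shows (nitro in place of chloro on an aromatic carbon). Among the compounds with values here, with no step measured between any two compounds, the change from compound 3 to compound 4 is expected to stay within the scatter of this assay, neither clearly up nor down. Compound 4 is therefore estimated at 50%, with a likely range from 25% to 78%.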

Compound 4, a percentage reported as inhibition, at one concentration (the size of the read-out at that concentration, not a potency): "active" (no number reported)
Compound 4: no number reported, so the estimate cannot be set against anything.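

In this assay, within the data shown here, compound 3 and compound 4 both stand without a figure, so no step from chloro to nitro can be read between them, and no other data here bear on this result. Going by these compounds, whether the 4-nitrophenyl and 4-chlorophenyl amides differ in inhibition stays open.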